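The source may hold more compounds than are shown below. What is called first, only, known or untested is meant among the compounds shown, and "the series" means these compounds.

In a functional assay on A549 cells (Homo sapiens) for antiproliferative activity, read by spectrophotometry, with a stated time of 2 days (on this read-out higher numbers stand for weaker inhibition of growth and lower numbers for stronger inhibition of growth), three compounds on a shared core differ only in the aryl group on a nitrogen on an aromatic ring. Compound 1 `COc1ccc(Nc2ncc(C(F)(F)F)c(N3Cc4cccc(N(C)S(C)(=O)=O)c4C3)n2)cc1C(F)(F)F` is reported only as a limit, > 30000 nM. Compound 2 `COc1cc(Nc2ncc(C(F)(F)F)c(N3Cc4cccc(N(C)S(C)(=O)=O)c4C3)n2)c(OC)cc1Cl` gives 7300 nM, and compound 3 `Cc1cc(Cl)ccc1Nc1ncc(C(F)(F)F)c(N2Cc3cccc(N(C)S(C)(=O)=O)c3C2)n1` gives 25500 nM. That is the higher of the two true numbers, with a 3.5-fold higher number from compound 2 to compound 3 (0.54 log units; beyond the scatter).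

Compound 4 `CN(c1cccc2c1CN(c1nc(Nc3ccc(Cl)c(C(F)(F)F)c3)ncc1C(F)(F)F)C2)S(C)(=O)=O` carries 4-chloro-3-(trifluoromethyl)phenyl in place of 4-chloro-2-methylphenyl on a nitrogen on an aromatic ring. The closest evidence is the 4-methoxy-3-(trifluoromethyl)phenyl group of compound 1, which shares the trifluoromethyl group with the entering aryl. Its comparison with the group that leaves is an at least 1.1-fold lower number from compound 1 to compound 3 (0.07 log units; that floor lies within the scatter), whose floor shows no separation beyond the scatter. The larger at least 4.1-fold lower number from compound 1 to compound 2 (0.61 log units; beyond the scatter) belongs to the 4-chloro-2,5-dimethoxyphenyl group, which compound 4 does not carry, so it bears on this change only weakly.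

No step beyond the scatter is therefore expected in this assay, and a result reported only as a limit would not be surprising. The expected step is a 1.3-fold lower number from compound 3 to compound 4 (0.11 log units; within the scatter). For compound 4 the estimated value is 20000 nM, with an expected range from 7000 nM to 35000 nM.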

Compound 4, concentration for 50% growth inhibition: 15200 nM
Compound 4: middle estimate off by 1.3-fold (0.12 log units), on the high side; low and high end bracket the measured number.
By their numbers in this assay, from the lowest: compound 2; then compounds 4 and 3 (each within the scatter of the next). At a limit, above all of these: compound 1.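

In this assay, the exchange of 4-chloro-2-methylphenyl for 4-chloro-3-(trifluoromethyl)phenyl gives a 1.7-fold lower number from compound 3 to compound 4 (0.22 log units; within the scatter), so at this position a trifluoromethyl-bearing aryl group with chloro cannot be told apart from the methyl-bearing one. The 4-chloro-2,5-dimethoxyphenyl group now stands apart from a second aryl group as well, with a 2.1-fold higher number from compound 2 to compound 4 (0.32 log units; beyond the scatter), a modest step that shows the lower number of compound 2 is not tied to a single comparison. The exchange of chloro for methoxy on an aromatic carbon, in the one pair here that keeps the trifluoromethyl group in both compounds, reads an at least 1.9-fold lower number from compound 1 to compound 4 (0.29 log units; that floor lies within the scatter), and this is only a floor set by a limit and not by a number: the limit of > 30000 nM in this assay, at which 1 of the 4 values shown sits.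

Still open, on these data alone, is how the read-out would respond if the trifluoromethyl group of compound 4 gave way to a nitrile or a carboxylic acid, or if the aryl group on this nitrogen gave way to a saturated amine such as morpholine. Also open, as far as these compounds go, is which of the two methoxy groups of compound 2 goes with its lower number, a question that an aryl group with chloro and a single methoxy group would address.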